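The source may hold more compounds than are shown below. What is called first, only, known or untested is meant among the compounds shown, and "the series" means these compounds.

Measured compounds:
- compound 1, `C#CCNC1CCc2c(OCCCCCN3CCN(c4cccc5c4ccn5Cc4cccc(Cl)c4)CC3)cccc21`: in an assay on HEK293 cells for displacement of a labelled ligand from 5-hydroxytryptamine receptor 6 (Homo sapiens), read by scintillation counting, with a stated time of 1 h (on this read-out lower numbers stand for stronger inhibition and higher numbers for weaker inhibition), compound 1 gives 223 nM
- compound 2, `C[C@H](NCc1ccc(OCCCN2CCN(c3cccc4c3ccn4Cc3cccc(Cl)c3)CC2)cc1)C(N)=O`: compound 2 gives 158 nM
- compound 3, `C[C@H](NCc1ccc(OCCCCN2CCN(c3cccc4c3ccn4Cc3cccc(Cl)c3)CC2)cc1)C(N)=O`: compound 3 gives 162 nM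

All three numbers sit close together, so compound 3 cannot be ranked against compound 1 or compound 2 beyond the usual scatter. Compound 4, `C[C@H](NCc1ccc(OCCCCN2CCN(c3cccc4c3ccn4S(=O)(=O)c3ccccc3)CC2)cc1)C(N)=O`, keeps the whole chain and amide portion of compound 3 and differs only at one point: phenylsulfonyl in place of 3-chlorobenzyl on an aromatic nitrogen. Among the measured compounds shown here, no measured pair shows this exchange, so its effect cannot be read from the data. Since the three measured compounds vary elsewhere without moving the number, the only open question is this new group. The estimate is a moderate gain, with the step from compound 3 to compound 4 expected at a 2.7-fold lower number from compound 3 to compound 4 (0.43 log units; beyond the scatter). Compound 4 is expected to give about 60 nM, plausibly between 10 nM and 400 nM.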

Compound 4, inhibition constant: 68 nM
The estimate for compound 4 lay 1.1-fold (0.05 log units) below the measured number; the range from low to high includes it.
By their numbers in this assay, from the lowest: compound 4; then compounds 2, 3 and 1 (each within the scatter of the next).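

Among the compounds shown here, all the earlier compounds carry 3-chlorobenzyl on this aromatic nitrogen, so they could not show whether the position responds to change. In this assay, phenylsulfonyl in place of 3-chlorobenzyl gives a 2.4-fold lower number from compound 3 to compound 4 (0.38 log units; beyond the scatter), a modest step but one beyond the scatter, so this position does affect the number. Nothing available explains this step.

From the compounds shown here alone, the change swaps the link to the aromatic ring and removes the chlorine at once, so their shares remain unknown. Unsubstituted benzyl or 3-chlorophenylsulfonyl on the same nitrogen would separate the two.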